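Working notes: a substituted aryl analogue of compound 3

A few compounds are considered here, and "the series" means these few. Any claim that something is new, unique, unknown or untested is made for them only; others in the source may bear on it.

Measured so far in a functional assay on KYSE-410 cells (Homo sapiens) for antiproliferative activity, read by MTT assay, with a stated time of 72 h; a higher number here means a weaker inhibitor, a lower number a stronger inhibitor:
Compound 1 `O=C(c1cc(=O)[nH]c2cc(Br)ccc12)N1CCCCC1` gives > 20000 nM, a limit of the assay.
Compound 2 `O=C(Nc1cc(F)c(F)c(F)c1)c1cc(=O)[nH]c2cc(Br)ccc12` gives > 20000 nM, a limit of the assay.
Compound 3 `O=C(Nc1cccc(F)c1)c1cc(=O)[nH]c2cc(-c3ccccc3)ccc12` gives > 20000 nM, a limit of the assay.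

Within the data shown here, compound 3 stands only at a limit in this assay, with no number of its own; this holds for (the limit of > 20000 nM in this assay, at which 3 of the 3 values shown sit), so no measured step exists within the set and nothing here separates one compound from another.

Compound 4 `Cc1cc(-c2ccc3c(C(=O)Nc4cccc(F)c4)cc(=O)[nH]c3c2)c(C)cc1F` differs from compound 3 by 4-fluoro-2,5-dimethylphenyl in place of phenyl on an aromatic carbon. Among the measured compounds shown here, no step between measured compounds is known on which to rest a direction, so no step beyond the scatter is expected in this assay; the estimated step is an at least 1.1-fold lower number from compound 3 to compound 4 (0.04 log units; that floor lies within the scatter). Compound 4 is expected to give about 18000 nM, within 6000 nM to 40000 nM, and most probably again only a limit.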

Compound 4, half-maximal inhibitory concentration: > 20000 nM
Compound 4: only a limit was reported (the forecaster's own chance of this, stated with the estimate: 65%); at least 1.1-fold (0.04 log units) between middle value and limit.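

Compound 3 and compound 4 both stand only at a limit, so no step can be read between them: the limit of > 20000 nM in this assay, at which 4 of the 4 values shown sit.

The compounds shown leave open the size of the change from phenyl to 4-fluoro-2,5-dimethylphenyl, and whether any such structure gives a number of its own in this assay.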